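Swapping a dichlorophenyl for a pyridine ring

The compounds below may be only part of what the source reports. "The series", "measured", "known", "first", "only" and "open" are said of these compounds alone.

Three compounds sharing one core have been tested in a functional assay on the whole organism with Rattus norvegicus as the target; on this read-out lower numbers stand for an effect already at smaller amounts and higher numbers for an effect only at larger amounts of compound:
Compound 1, `CC1CCC(=NNc2ccccc2C(=O)O)c2ncc(C(=O)O)c(=O)n21`, gives 0.48 umol/kg.
Compound 2, `CC1CCC(=NNc2ccc(Cl)c(Cl)c2)c2ncc(C(=O)O)c(=O)n21`, gives 0.89 umol/kg.
Compound 3, `COc1cc(NN=C2CCC(C)n3c2ncc(C(=O)O)c3=O)cc(OC)c1`, gives 0.42 umol/kg.

Compound 2 stands at the highest of these three numbers. Its gap to compound 1 lies within the scatter of repeated measurements, while compound 3 sits beyond that scatter with a lower number. Compound 4, `CC1CCC(=NNc2cccnc2)c2ncc(C(=O)O)c(=O)n21`, has not yet been measured. It differs from compound 2 in one place: pyridin-3-yl in place of 3,4-dichlorophenyl on an amine nitrogen. Within the data shown here, none of the measured compounds shows how this kind of change acts in this assay. A small step is expected, no larger than the scatter, in either direction. Compound 4 is therefore estimated at 0.8 umol/kg, within a range from 0.3 umol/kg to 2.5 umol/kg. That estimate means a step of a 1.1-fold lower number from compound 2 to compound 4 (0.05 log units; within the scatter) is expected.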

Compound 4, dose for 50% inhibition: 0.54 umol/kg
Compound 4: the middle estimate sits 1.5-fold (0.17 log units) above what was measured; the measured number falls inside the stated range.
By their numbers in this assay, from the lowest: compounds 3, 1, 4 and 2 (each within the scatter of the next, the first and the last beyond it).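

Putting pyridin-3-yl in place of 3,4-dichlorophenyl on an amine nitrogen gives a 1.6-fold lower number from compound 2 to compound 4 (0.22 log units; within the scatter) in this assay. Among these compounds, this is the first single change seen at this position, and it shows that both chlorines can go and a ring nitrogen can come in without a step beyond the scatter. No measurement shown explains this result.

Still open, from the compounds shown here alone, is whether this position needs an aromatic ring at all, since a piperidine ring or a plain methyl group could give a very different number. The same question applies to a longer chain ending in a carboxylic acid.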